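Fluoro-to-chloro swaps across two cores

A few compounds are considered here, and "the series" means these few. Any claim that something is new, unique, unknown or untested is made for them only; others in the source may bear on it.

Measured so far:
Compound 1, `O=C(Nc1ccc(F)cc1)c1ccnc2cc(Br)ccc12`, in a functional assay on KYSE-70 cells for antiproliferative activity against KYSE-70 cell line (Homo sapiens), read by MTT assay, with a stated time of 72 h (a higher number here means a weaker inhibitor, a lower number a stronger inhibitor), gives > 20000 nM; this is a limit of the assay.
Compound 2, `O=C(Nc1ccc(Cl)cc1)c1ccnc2cc(Br)ccc12`, in this assay gives > 20000 nM, again a limit.
Compound 3, `O=C(Nc1cc(F)cc(F)c1)c1cc(=O)[nH]c2cc(F)ccc12`, in this assay gives > 20000 nM, also a limit.

Compounds 1 and 2 share one core, compound 3 another; the difference between the two cores is not broken down here. The step that the two limits leave unreadable from compound 1 to compound 2 goes with chloro in place of fluoro on an aromatic carbon. Compound 4, `O=C(Nc1cc(F)cc(F)c1)c1cc(=O)[nH]c2cc(Cl)ccc12`, not yet measured, differs from compound 3 by chloro in place of fluoro on an aromatic carbon. Its place reads "part of a fused or bridged system of two rings; meta to a fused ring; para to a fused ring", where the first pair reads "para to a large group", so this is the same kind of change, not the same. Because (the limit of > 20000 nM in this assay, at which 3 of the 3 values shown sit), the measured step gives no size to carry over. In this assay compound 4 is expected to give 30000 nM. The expected step that the limit leaves unreadable from compound 3 to compound 4 rests on compound 3 sitting at a limit and on the unread step that the two limits leave unreadable from compound 1 to compound 2.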

Compound 4, half-maximal inhibitory concentration: 9000 nM
Compound 4: middle estimate off by 3.3-fold (0.52 log units), on the high side, and the stated range covers the measured number.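

In this assay, chloro in place of fluoro on an aromatic carbon gives an at least 2.2-fold lower number from compound 3 to compound 4 (0.34 log units; beyond the scatter); the true size may be larger, as compound 3 sits at a limit. The same swap between compound 1 and compound 2 cannot be read, because both values are limits: the limit of > 20000 nM in this assay, at which 3 of the 4 values shown sit.

The series therefore shows the change lowering the number on one core only, and does not show that the step carries from one core to the other, particularly as the two swaps sit at different places. Still open, on these data alone, is whether an amine or a carboxylic acid at the place of the chloro in compound 4 would lower the number further.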